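The compounds below may be only part of what the source reports. "The series", "measured", "known", "first", "only" and "open" are said of these compounds alone.

Compound 1 `COC(=O)C1C(=O)C=C(Nc2ccccc2N2CCN(C)CC2)CC1c1ccccc1` and compound 2 `COC(=O)C1C(=O)C=C(Nc2cccc(N3CCN(C)CC3)c2)CC1c1ccccc1` are built from the same atoms joined differently; how the two cores differ is not broken down here. In a physicochemical assay for lipophilicity (on this read-out higher numbers stand for higher lipophilicity and lower numbers for lower lipophilicity), compound 1 gives 3.97, and compound 2 gives 3.99, two numbers within the usual scatter of each other. Compound 3 `COC(=O)C1C(=O)C=C(Nc2cccc(N3CCN(C)CC3)c2)CC1C` carries the change (methyl in place of phenyl on a saturated ring carbon), and in this assay compound 3 gives 2.67, so that the step of a number 1.32 log units lower from compound 2 to compound 3 (beyond the scatter) is large and well beyond the scatter.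

Compound 4 `COC(=O)C1C(=O)C=C(Nc2ccccc2N2CCN(C)CC2)CC1C` has not yet been measured in this assay. Among the compounds with values here, it carries the change (methyl in place of phenyl on a saturated ring carbon), which is the same change as the one from compound 2 to compound 3, at the same place on the saturated ring. Because the step of a number 1.32 log units lower from compound 2 to compound 3 (beyond the scatter) was large, a step of about the same size is expected for compound 4, namely a number 1.32 log units lower from compound 1 to compound 4 (beyond the scatter). On this basis compound 4 is estimated to come out at 2.65 in this assay, most likely between 2.35 and 2.95.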

Compound 4, partition coefficient: 2.65
For compound 4 middle estimate and measured number coincide at the digits printed, and the stated range covers the measured number.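

In this assay the change from phenyl to methyl on a saturated ring carbon gives a number 1.32 log units lower from compound 1 to compound 4 (beyond the scatter) and so matches in size a number 1.32 log units lower from compound 2 to compound 3 (beyond the scatter), which means the step carried over from the core of compound 2 to the core of compound 1. This rests on just two matched pairs, so it shows that the step held in these two cores and gives no rule for other cores in the series or for any other read-out. Nothing shown here explains why the step is so large or why it repeats.

The compounds shown carry only phenyl or methyl on this ring carbon, so what a longer chain such as ethyl, an amine or a carboxylic acid would give there remains open. On these data alone, whether the step would hold with a carboxylic acid in place of the methoxycarbonyl group also remains open.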